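Turning One Double Bond in a Short-Lived Compound

The compounds below may be only part of what the source reports. "The series", "measured", "known", "first", "only" and "open" are said of these compounds alone.

In a physicochemical assay for pharmacokinetics, read by fluorescence and HPLC, with a stated time of 24 h (a higher number here means that the compound lasts longer, a lower number that the compound disappears faster), compound 1 `CC(C)(C)C1=C(C(=O)O)N2C(=O)/C(=C\c3ccccc3)C2O1` gives 0.17 h and compound 2 `CC(C)(C)C1=C(C(=O)O)N2C(=O)/C(=C/c3ccoc3)C2O1` gives 0.32 h. These two numbers lie within the usual scatter of repeated measurements, so they cannot be told apart, and compound 2 stands level with compound 1. Both disappear within a small part of the stated time of the measurement.

The next compound changes very little. Compound 3 `CC(C)(C)C1=C(C(=O)O)N2C(=O)/C(=C\c3ccoc3)C2O1` has the same atoms and bonds as compound 2, but a double bond is drawn E in compound 2 and Z in compound 3 (the two compounds have the same atoms and bonds; at least one stereo element is drawn with a configuration in one of them and without one in the other: 1 of 2 stereo elements differ; a double bond is drawn E in compound 2 and Z in compound 3). Nothing leaves and nothing enters, so only the arrangement at that double bond is different.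

Among the measured compounds shown here, no measured pair shows what such a switch does in this assay, so the data offer no firm direction. The starting point is compound 2 at 0.32 h, and the expectation stays close to it. The estimated step of a 1.3-fold lower number from compound 2 to compound 3 (0.11 log units; within the scatter) is small and expected to stay within the scatter. Compound 3 is expected at 0.25 h, with an estimated range from 0.1 h to 0.7 h.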

Compound 3, half-life: 0.38 h
Beside the measured number, compound 3's estimate is 1.5-fold (0.18 log units) below it; measured number inside the range.
By their numbers in this assay, from the lowest: compounds 1, 2 and 3 (each within the scatter of the next, the first and the last beyond it).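

In this assay the switch at the double bond gives a 1.2-fold higher number from compound 2 to compound 3 (0.07 log units; within the scatter), so the arrangement there shows no effect that can be told apart from the spread of repeated measurements. Compound 3 also allows a second comparison, with furan-3-yl in place of phenyl on a double-bonded chain carbon bound to a double-bonded ring carbon: a 2.2-fold higher number from compound 1 to compound 3 (0.35 log units; beyond the scatter), a modest step and the first among these compounds that stands clear of the scatter. The comparison of the two furan-3-yl compounds has to be read with one reservation: the fact that one of compounds 2 and 3 is drawn with a defined configuration and the other without, at the place where they differ.

From the compounds shown here alone, one phenyl compound and two furan-3-yl compounds are a narrow base, so it stays open whether the modest rise in half-life belongs to furan-3-yl alone or would also appear with another ring, such as thiophene or pyridine. Going by these compounds, it also stays open whether an amine or a longer chain in place of furan-3-yl would lengthen the half-life further, since all three compounds still disappear within a small part of the stated time of the measurement.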